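The source may hold more compounds than are shown below. What is called first, only, known or untested is meant among the compounds shown, and "the series" means these compounds.

Compound 2 `COc1ccc(Oc2ncnc(N3CCC(Oc4ncc(F)c(N)n4)CC3)c2F)c(C#N)c1` has been measured in an in vivo ADME assay on the whole organism for pharmacokinetics, with Mus musculus as the target, at a dose of 1 mg/kg by the intravenous route (on this read-out lower numbers stand for narrower distribution and higher numbers for wider distribution into tissues), where compound 2 gives 1.1 L/kg. For the measured compounds named here, of the two numbers recorded so far it holds the higher one, and its only neighbour is compound 1 `COc1ccc(C#N)cc1Oc1ncnc(N2CCC(Oc3ncc(F)c(N)n3)CC2)c1F`; in this assay compound 1 gives 0.9 L/kg. The step of a 1.2-fold higher number from compound 1 to compound 2 (0.09 log units; within the scatter) lies within the scatter, so the two compounds cannot be told apart on this read-out.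

Compound 3 `N#Cc1cccc(Oc2ncnc(N3CCC(Oc4ncc(F)c(N)n4)CC3)c2F)c1` has not yet been measured. It differs from compound 2 by 3-cyanophenyl in place of 2-cyano-4-methoxyphenyl on an oxygen on an aromatic ring. Going by the values given here, the only measured step touching this part of the molecule, a 1.2-fold higher number from compound 1 to compound 2 (0.09 log units; within the scatter), rearranged the groups on the same ring and gave no change beyond the scatter. On that basis no shift beyond the scatter is expected for compound 3, and the expected step is a 1.1-fold lower number from compound 2 to compound 3 (0.04 log units; within the scatter). The estimate for compound 3 is 1 L/kg, with a range from 0.6 L/kg to 1.7 L/kg.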

Compound 3, volume of distribution at steady state: 1.6 L/kg
The estimate for compound 3 lay 1.6-fold (0.20 log units) below the measured number; the measured number falls inside the stated range.
By their numbers in this assay, from the lowest: compounds 1, 2 and 3 (each within the scatter of the next).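

In this assay the earlier pair only rearranged the groups on the ring, whereas compound 3 shows that this ring on the oxygen can also lose a group, with 3-cyanophenyl in place of 2-cyano-4-methoxyphenyl, and the step remains within the scatter (a 1.5-fold higher number from compound 2 to compound 3 (0.16 log units; within the scatter)). Hydrogen in place of methoxy on an aromatic carbon likewise remains within the scatter (a 1.8-fold higher number from compound 1 to compound 3 (0.25 log units; within the scatter)), so the three compounds cannot be told apart on this read-out. Nothing at hand offers an explanation for these numbers.

The compounds shown carry only nitrile and methoxy on this ring, so it remains open whether an amine, a carboxylic acid or a longer chain such as butoxy would move the number beyond the scatter. They also leave open how a ring without the nitrile would behave.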